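Methyls to Chlorines: Expected Cytotoxicity of Compound 3

The compounds below may be only part of what the source reports. "The series", "measured", "known", "first", "only" and "open" are said of these compounds alone.

Compound 1 `Cc1ccc(OCCn2ccc(=O)n(Cc3cc(C)cc(C)c3)c2=O)cc1` gives only a limit, > 343000 nM. Compound 2 `Cc1cc(C)cc(Cn2c(=O)ccn(C/C=C/c3ccccc3)c2=O)c1` gives 257000 nM.

In an ADME assay on MT4 cells (Homo sapiens) for cytotoxicity, read by MTT assay, with a stated time of 4 days (a higher number here means that more compound is tolerated, a lower number that less compound is tolerated), the value of compound 1 is a limit, not a number. Compound 2 holds the only number shown, the other value being the limit (the limit of > 343000 nM in this assay, at which 1 of the 2 values shown sits). Going by the values given here, the one measured step, an at least 1.3-fold lower number from compound 1 to compound 2 (0.12 log units; that floor lies within the scatter), lies within the scatter and touches a different part of the molecule.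

Compound 3 `O=c1ccn(C/C=C/c2ccccc2)c(=O)n1Cc1cc(Cl)cc(Cl)c1` differs from compound 2 by 3,5-dichlorophenyl in place of 3,5-dimethylphenyl on a saturated chain carbon bound to an aromatic nitrogen. Among the compounds with values here, no measured step bears on this change, so no shift beyond the scatter is expected: a 1.3-fold lower number from compound 2 to compound 3 (0.11 log units; within the scatter). Compound 3 is expected near 200000 nM, between 70000 nM and 400000 nM.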

Compound 3, half-maximal cytotoxic concentration: 49000 nM
Compound 3: middle estimate off by 4.1-fold (0.61 log units), on the high side; measured number below the stated range.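

In this assay, the group on the saturated chain carbon bound to an aromatic nitrogen proves to matter: 3,5-dichlorophenyl in place of 3,5-dimethylphenyl gives a 5.2-fold lower number from compound 2 to compound 3 (0.72 log units; beyond the scatter), so less compound is tolerated. The earlier step changed a different part of the molecule and stayed within the scatter, so it could not show this. Nothing measured here points to a reason for the shift.

Still open, as far as these compounds go, is whether a single chlorine, or an amine or a carboxylic acid on this ring, would move the number. Also open, from the compounds shown here alone, is whether the same change acts alike when (4-methylphenoxy)methyl replaces 2-phenylethenyl.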